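Chlorobenzyl positional swap across two cores, oral artery inhibition

A few compounds are considered here, and "the series" means these few. Any claim that something is new, unique, unknown or untested is made for them only; others in the source may bear on it.

Compound 1 `COc1ccc(C2N=C(SCc3ccccc3Cl)NC(C)=C2C(=O)Nc2ccc(F)cc2)cc1OC` and compound 2 `COc1ccc(C2N=C(SCc3cccc(Cl)c3)NC(C)=C2C(=O)Nc2ccc(F)cc2)cc1OC` share one core; compound 2 differs from compound 1 by 3-chlorophenyl in place of 2-chlorophenyl on a saturated chain carbon bound to a sulfur. In a functional assay on the whole organism (artery, strain albino) with Rattus norvegicus as the target, with a stated time of 30 min, at a dose of 10 mg/kg by the oral route (a higher number here means more inhibition at the dose given (going by the name of the read-out), a lower number less inhibition), compound 1 gives 6.2% and compound 2 gives 5.2%, a step of a number 1 percentage points lower from compound 1 to compound 2 (within the scatter). Compound 3 `CC1=C(C(=O)Nc2ccc(Br)cc2)C(c2ccc(Cl)cc2Cl)N=C(SCc2ccccc2Cl)N1` sits on another core; the difference between the two cores is not broken down here. In this assay compound 3 gives 5.7%. Compound 4 `CC1=C(C(=O)Nc2ccc(Br)cc2)C(c2ccc(Cl)cc2Cl)N=C(SCc2cccc(Cl)c2)N1` differs from compound 3 by 3-chlorophenyl in place of 2-chlorophenyl on a saturated chain carbon bound to a sulfur, the same change as between compound 1 and compound 2, at the same place. Since the earlier step from compound 1 to compound 2, a number 1 percentage points lower from compound 1 to compound 2 (within the scatter), stayed within the scatter, the step from compound 3 to compound 4 is expected to be small too, a number 1 percentage points lower from compound 3 to compound 4 (within the scatter). For compound 4 the inhibition in this assay is estimated at 4.7%, expected between -3% and 13%.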

Compound 4, a percentage reported as inhibition, in the whole organism at one dose (the size of the read-out at that dose, not a potency): 3.1%
The estimate for compound 4 lay 1.6 percentage points above the measured number, within the range that was stated.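

In this assay, 3-chlorobenzyl in place of 2-chlorobenzyl gives a number 2.6 percentage points lower from compound 3 to compound 4 (within the scatter), and set beside the earlier step on the other core it reads: the same change on two cores in this assay, a number 1 percentage points lower (within the scatter) from compound 1 to compound 2 and a number 2.6 percentage points lower (within the scatter) from compound 3 to compound 4, 1.6 percentage points apart, within the scatter of two such steps. Going by these compounds alone, on these two cores, the change therefore carries over with no step or gap that can be told from the scatter. This does not show that the change would stay as small on any further core, nor does it show a real loss of inhibition on either core.

The compounds shown leave open whether a different group on the sulfur, such as unsubstituted benzyl, a longer alkyl chain, or a chain ending in an amine or a carboxylic acid, would move the inhibition beyond the scatter.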